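A few compounds are considered here, and "the series" means these few. Any claim that something is new, unique, unknown or untested is made for them only; others in the source may bear on it.

In a functional assay for antagonist activity at transient receptor potential cation channel subfamily V member 1 (Rattus norvegicus) (on this read-out higher numbers stand for weaker inhibition and lower numbers for stronger inhibition), three compounds that share a core have been measured. Compound 1 `CC(C)(C)c1ccc(CCC(=S)NCc2ccc(NS(C)(=O)=O)c(F)c2)cc1` gives 40 nM, compound 2 `C=Cc1cc(CNC(=S)CCc2ccc(C(C)(C)C)cc2)cc(F)c1NS(C)(=O)=O` gives 32 nM, and compound 3 `CC(C)(C)c1ccc(CCC(=S)NCc2cc(F)c(NS(C)(=O)=O)c(C3CC3)c2)cc1` gives 270 nM, the highest number of the three. Two measured steps reach compound 3: a 6.8-fold higher number from compound 1 to compound 3 (0.83 log units; beyond the scatter) and an 8.4-fold higher number from compound 2 to compound 3 (0.93 log units; beyond the scatter), each putting cyclopropyl onto the aromatic carbon. Compound 4 `CC(C)(C)c1ccc(CCC(=S)NCc2cc(F)c(NS(C)(=O)=O)c(C#N)c2)cc1` differs from compound 3 in one place: cyano in place of cyclopropyl on an aromatic carbon. Both steps bear on this change, since the cyclopropyl that raised the number is now removed, and the number for compound 4 is expected to fall back, roughly toward compound 1, because a 6.8-fold higher number from compound 1 to compound 3 (0.83 log units; beyond the scatter) is reversed in kind. Compound 4 is therefore expected to show a 5.4-fold lower number from compound 3 to compound 4 (0.73 log units; beyond the scatter). Compound 4 is estimated at 50 nM, within 15 nM to 200 nM.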

Compound 4, half-maximal inhibitory concentration: 28 nM
Compound 4: middle estimate off by 1.8-fold (0.25 log units), on the high side; measured number inside the range.
By their numbers in this assay, from the lowest: compounds 4, 2 and 1 (each within the scatter of the next); then compound 3.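

Cyano in place of cyclopropyl brings a 9.6-fold lower number from compound 3 to compound 4 (0.98 log units; beyond the scatter) and so shows that the high number of compound 3 does not extend to every group on this aromatic carbon. Cyano also sits level with vinyl and hydrogen here, as a 1.1-fold lower number from compound 2 to compound 4 (0.06 log units; within the scatter) and a 1.4-fold lower number from compound 1 to compound 4 (0.15 log units; within the scatter) show, which leaves cyclopropyl as the only one of these four groups that stands apart. Nothing available explains this difference.

On these data alone, it remains open how an amine, a carboxylic acid or a longer chain would behave on this carbon, and whether ethyl would track vinyl or cyclopropyl.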